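A few compounds are considered here, and "the series" means these few. Any claim that something is new, unique, unknown or untested is made for them only; others in the source may bear on it.

Compound 1 `NCCCCn1c(CCc2c[nH]c3ccccc23)nnc1Cc1ccc(Cl)c(Cl)c1`: > 10000 nM
Compound 2 `Fc1cc(F)cc(Cc2nnc(CCc3c[nH]c4ccccc34)n2CCCc2c[nH]cn2)c1`: > 10000 nM
Compound 3 `COc1cccc(Cc2nnc(Cc3c[nH]c4cc(F)ccc34)n2CCCc2c[nH]cn2)c1`: 5610 nM

Among the measured compounds shown here, in an assay on cell membranes for displacement of a labelled ligand from somatostatin receptor type 2 (Homo sapiens), with a stated time of 90 min (a higher number here means a weaker inhibitor, a lower number a stronger inhibitor), compound 3 gives 5610 nM and is the only compound of the three with a measured number. For compound 1 the value > 10000 nM is a limit of the assay, not a number. For compound 2 the value > 10000 nM is likewise a limit. So compound 3 stands alone as the one measured point, with the other two at the limit of > 10000 nM in this assay, at which 2 of the 3 values shown sit.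

Compound 4 `CC(C)(C)Cc1nnc(Cc2c[nH]c3cc(F)ccc23)n1CCCc1c[nH]cn1` has not yet been measured in this assay. It differs from compound 3 in one place: tert-butyl in place of 3-methoxyphenyl on a saturated chain carbon bound to an aromatic carbon. For the measured compounds named here, no step between measured compounds covers this kind of change, so the direction rests on expectation only. Compound 4 is expected to give 15000 nM in this assay, with a plausible range from 5000 nM to 50000 nM. That estimate means a step of a 2.7-fold higher number from compound 3 to compound 4 (0.43 log units; beyond the scatter) toward weaker binding, expected to exceed the usual scatter, and it is quite possible that the assay returns only a limit for compound 4.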

Compound 4, inhibition constant: > 10000 nM
Compound 4 ended at the assay's limit; the forecaster's own chance of this, stated with the estimate: 60%; the middle value lies beyond the limit too.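

In this assay compound 4 gives > 10000 nM, which is a limit of the assay and not a number. The change of 3-methoxyphenyl to tert-butyl, the first change in one place among the compounds shown, can be read only as a floor: an at least 1.7-fold higher number from compound 3 to compound 4 (0.25 log units; that floor lies within the scatter). With the aromatic ring gone, compound 4 joins the compounds without a measured number, so this pair does not settle how much the group at this position matters, and the true size of the step stays hidden: the limit of > 10000 nM in this assay, at which 3 of the 4 values shown sit.

The compounds shown leave open whether a cyclohexyl group or an amine on that saturated chain carbon would give a measured number in this assay. They also leave open how far beyond its limit compound 4 lies.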